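The compounds below may be only part of what the source reports. "The series", "measured", "known", "first", "only" and "open" are said of these compounds alone.

Measured in a functional assay on CAKI-1 cells (Homo sapiens) for inhibition, read by sulforhodamine B assay, with a stated time of 48 h, tested at 0.1 uM; a higher number here means a weaker effect of the compound at the concentration tested, a lower number a stronger effect:

Compound 1, `O=C(Nc1cccc(-n2cc(-c3ccncc3)c(-c3cc(O)cc(Cl)c3)n2)c1)Nc1ccc(Cl)c(C(F)(F)F)c1`: 103%
Compound 2, `O=C(Nc1cccc(-n2cc(-c3ccncc3)c(-c3cc(O)cc(Cl)c3)n2)c1)Nc1ccc(Cl)c(Cl)c1`: 98%
Compound 3, `COc1cc(Cl)cc(-c2nn(-c3cccc(NC(=O)Nc4cc(C(F)(F)F)cc(C(F)(F)F)c4)c3)cc2-c2ccncc2)c1`: 95%

All three numbers sit close together. Within the data shown here, compound 3 has the lowest of the three, but its nearest neighbour is compound 2, differing by an amount within the scatter, and even the furthest, compound 1, differs from it by an amount within the scatter, so no compound can be called stronger or weaker than another here.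

Compound 4, `COc1cc(Cl)cc(-c2nn(-c3cccc(NC(=O)Nc4cccc(C(F)(F)F)c4)c3)cc2-c2ccncc2)c1`, is not yet measured. It differs from compound 3 in one place: hydrogen in place of trifluoromethyl on an aromatic carbon. Among the measured compounds shown here, the only measured step of a comparable kind is a number 5 percentage points lower from compound 1 to compound 2 (within the scatter), where one group on an aromatic carbon was swapped for another without a change beyond the scatter. For the measured compounds named here, no measured step removes a group entirely, so the bearing of that step is indirect. Given how close all three measured numbers lie, the expected step is a number 2 percentage points higher from compound 3 to compound 4 (within the scatter), that is, none beyond the scatter. Compound 4 is therefore estimated at 97%, with a range from 85% to 108%.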

Compound 4, a percentage reported as activity, at one concentration (the size of the read-out at that concentration, not a potency): 104%
Compound 4: middle estimate off by 7 percentage points, on the low side; the range from low to high includes it.
By their numbers in this assay, from the lowest: compounds 3, 2, 1 and 4 (each within the scatter of the next).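

Replacing trifluoromethyl with hydrogen on this aromatic carbon, meta to the trifluoromethyl group that stays, gives a number 9 percentage points higher from compound 3 to compound 4 (within the scatter) in this assay. Unlike the earlier swap of one group for another, this step removes a group outright, taking away 4 heavy atoms, and still produces no change beyond the scatter. No separate measurement bears on this result.

From the compounds shown here alone, whether a different group on this carbon, such as an amine or a carboxylic acid, would give a step beyond the scatter remains open. With no step shown so far going beyond the scatter in this assay, the compounds also leave open whether this position has any influence on the read-out at all.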